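Para Chloro in Place of Para Methyl

The source may hold more compounds than are shown below. What is called first, only, known or untested is meant among the compounds shown, and "the series" means these compounds.

Measured so far:
compound 1 `Cc1cccc(C#Cc2ccc3c(n2)CCN(C2CCCC2)C3=O)c1`: 670 nM
compound 2 `Cc1ccc(C#Cc2ccc3c(n2)CCN(C2CCCC2)C3=O)cc1`: > 32000 nM
compound 3 `O=C1c2ccc(C#Cc3ccc(Cl)cc3)nc2CCN1C1CCCC1`: not yet measured

In an assay on HEK293 cells for displacement of a labelled ligand from metabotropic glutamate receptor 5 (Homo sapiens), with a stated time of 2 h (a lower number here means a stronger inhibitor, a higher number a weaker inhibitor), compound 1 gives 670 nM. For compound 2 only a limit of the assay is known, (the limit of > 32000 nM in this assay, at which 1 of the 2 values shown sits). Among the compounds with values here, the one measured step, an at least 47-fold higher number from compound 1 to compound 2 (1.67 log units; beyond the scatter), arises from moving the methyl group around the phenyl ring. Compound 3 differs from compound 2 by chloro in place of methyl on an aromatic carbon. Within the data shown here, that measured step speaks to where a group sits on the phenyl ring, not to chloro against methyl; no measured pair compares those two groups, so the direction of this change is unsupported by data. Since compound 2 already sits at the limit, the estimate for compound 3 stays near that limit, and the expected step of an at least 1.0-fold lower number from compound 2 to compound 3 (0.02 log units; that floor lies within the scatter) is taken as nothing beyond the scatter. Compound 3 is therefore estimated at 30000 nM, within the range 5000 nM to 150000 nM, with a sizeable chance that only a limit is reported again.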

Compound 3, inhibition constant: > 32000 nM
Compound 3 ended at the assay's limit (the forecaster's own chance of this, stated with the estimate: 55%); middle value at least 1.0-fold (0.02 log units) from the limit.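

Replacing methyl with chloro does not rescue the 4-substituted phenyl: 4-chlorophenyl in place of 3-methylphenyl gives an at least 47-fold higher number from compound 1 to compound 3 (1.67 log units; beyond the scatter) in this assay. The large loss seen with 4-methylphenyl therefore also appears with a second group, so it is not peculiar to methyl, although two compounds cannot establish a general rule. The step between compound 2 and compound 3 cannot be read, and methyl and chloro cannot be ranked at this position, because both values are limits: the limit of > 32000 nM in this assay, at which 2 of the 3 values shown sit.

Going by these compounds, it remains open whether a smaller or more polar group at this position, such as fluoro, methoxy or an amine, would restore binding. Also open, on these data alone, is whether chloro could replace the methyl of 3-methylphenyl while keeping binding close to the 670 nM of compound 1.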